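Swapping 3,4-dihydroxyphenyl for 4-methoxyphenyl on the shared core

The source may report more compounds than this note shows. Statements on the series, on what has been measured and on what is new or still open speak of the compounds shown alone.

Of the compounds shown here, three with a shared core have been measured in a functional assay on NCI-H520 cells (Homo sapiens) for cytotoxicity; a lower number here means a stronger inhibitor of growth, a higher number a weaker inhibitor of growth. Compound 1 `CSc1ccc(C2=C(c3ccc(C)c(C)c3)C(=O)N3CCCC3C2)cc1` gives 300 nM, compound 2 `CSc1ccc(C2=C(c3ccc(F)c(C)c3)C(=O)N3CCCC3C2)cc1` gives 500 nM, and compound 3 `CSc1ccc(C2=C(c3ccc(O)c(O)c3)C(=O)N3CCCC3C2)cc1` gives 60000 nM. Compound 3 therefore has the highest number of the three and is the weakest inhibitor of growth among them.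

The next compound, compound 4 `COc1ccc(C2=C(c3ccc(SC)cc3)CC3CCCN3C2=O)cc1`, differs from compound 3 in one group: 4-methoxyphenyl in place of 3,4-dihydroxyphenyl on a double-bonded ring carbon. In words, 4-methoxyphenyl stands in place of 3,4-dihydroxyphenyl on a double-bonded ring carbon.

Among the compounds with values here, two measured steps bear on this change, and both are large: a 200-fold higher number from compound 1 to compound 3 (2.30 log units; beyond the scatter), and a 120-fold higher number from compound 2 to compound 3 (2.08 log units; beyond the scatter). In each, a ring without hydroxy groups gives way to the 3,4-dihydroxyphenyl group. Compound 4 also lacks hydroxy groups on this ring, so the same kind of change is expected to run in reverse here. A third step, a 1.7-fold higher number from compound 1 to compound 2 (0.22 log units; within the scatter), suggests that this position can tolerate more than one kind of group. Within the data shown here, no measured compound carries a methoxy group, however, so the size of the step remains uncertain.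

The expected step is a 120-fold lower number from compound 3 to compound 4 (2.08 log units; beyond the scatter), a large move toward a lower number. The estimate for compound 4 is 500 nM, with an expected range from 100 nM to 3000 nM.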

Compound 4, concentration for 50% growth inhibition: 800 nM
Compound 4: the middle estimate sits 1.6-fold (0.20 log units) below what was measured; the measured number falls inside the stated range.
By their numbers in this assay, from the lowest: compounds 1, 2 and 4 (each within the scatter of the next, the first and the last beyond it); then compound 3.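

The change gives a 75-fold lower number from compound 3 to compound 4 (1.88 log units; beyond the scatter) in this assay, so a ring with a single oxygen-bearing group, 4-methoxyphenyl, sits far from the 3,4-dihydroxyphenyl ring of compound 3. This shows that an oxygen on this ring does not by itself bring the large rise in the number seen with compound 3. Against the two rings without oxygen the result is mixed: replacing 4-fluoro-3-methylphenyl gives a 1.6-fold higher number from compound 2 to compound 4 (0.20 log units; within the scatter), which is no real difference, while replacing 3,4-dimethylphenyl gives a 2.7-fold higher number from compound 1 to compound 4 (0.43 log units; beyond the scatter), a modest rise, so this position accepts a ring with one group as well as rings with two, at little or modest cost.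

No measurement shown here explains why the 3,4-dihydroxyphenyl ring stands so far from the others. As far as these compounds go, it also stays open whether a ring with a single hydroxy group, an amine or a carboxylic acid in this place would fall with compound 3 or with the other three compounds.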